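Compound 4: a cyclopropylsulfonyl pyrrolidine on the shared core

The source may report more compounds than this note shows. Statements on the series, on what has been measured and on what is new or still open speak of the compounds shown alone.

Among the compounds with values here, in a functional assay on NCI-H1975 cells (Homo sapiens) for antiproliferative activity, read by MTT assay, with a stated time of 72 h (on this read-out lower numbers stand for stronger inhibition and higher numbers for weaker inhibition), compound 1 `CN1CCN(c2ccc(Nc3ncc4nc(Nc5ccc(F)cc5)n([C@H]5CCCN(C(=O)CO)C5)c4n3)cc2)CC1` gives 750 nM and is the only compound with a number so far. Compound 2 `CC(=O)Nc1cccc(-n2c(Nc3ccc(F)cc3)nc3cnc(Nc4ccc(N5CCN(C)CC5)cc4)nc32)c1` stands at "not determined" (no result reported) and adds nothing to the scale. Going by these compounds, compound 3 `CN1CCN(c2ccc(Nc3ncc4nc(Nc5ccc(F)cc5)n([C@@H]5CCCN(C(=O)CO)C5)c4n3)cc2)CC1` stands at "not determined" (no result reported) as well, so its place on the scale remains open. Its nearest anchor is compound 1 (the fact that compounds 1 and 3 differ only in the configuration as drawn), although no measurement shows what that difference in configuration is worth. Compound 4 `CN1CCN(c2ccc(Nc3ncc4nc(Nc5ccc(F)cc5)n([C@H]5CCN(S(=O)(=O)C6CC6)C5)c4n3)cc2)CC1` has yet to be measured. The change is 1-(cyclopropylsulfonyl)pyrrolidin-3-yl in place of 1-((hydroxymethyl)carbonyl)piperidin-3-yl on an aromatic nitrogen and consists of 1-(cyclopropylsulfonyl)pyrrolidin-3-yl in place of 1-((hydroxymethyl)carbonyl)piperidin-3-yl on an aromatic nitrogen, with the rest of the structure unchanged. Within the data shown here, no step has been measured, so no direction is favoured in this assay and a shift beyond the usual scatter is not expected, taking compound 1 at 750 nM as the reference. For compound 4 the estimated value is 700 nM within an expected range from 200 nM to 2500 nM on this read-out.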

Compound 4, half-maximal inhibitory concentration: 580 nM
For compound 4 the middle estimate is 1.2-fold (0.08 log units) above the measured one; the range from low to high includes it.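

Within the data shown here, the first readable step at this aromatic nitrogen in this assay is a 1.3-fold lower number from compound 1 to compound 4 (0.11 log units; within the scatter). On this read-out, 1-(cyclopropylsulfonyl)pyrrolidin-3-yl therefore cannot be told apart from 1-((hydroxymethyl)carbonyl)piperidin-3-yl, even though the entering group has a five-membered ring in place of a six-membered one, a cyclopropyl ring and sulfur, and 0 hydrogen-bond donors. Nothing available explains this step.

Ring size and the group on the ring change together here, so a 1-(cyclopropylsulfonyl)piperidin-3-yl group would be needed to separate them, and an unsubstituted secondary amine or a carboxylic acid at the same place would test how far the position extends. Compound 2 and compound 3 have no number, so neither the aryl group at this nitrogen nor the other configuration can be read.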